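Replacing nitro with amino in compound 2

This account rests on a few compounds, and the source may have more. Where it says the series, first, only, none or still open, it means among the compounds named here.

Compound 1 `C/C(=N\NC(=O)c1ccc(O)cc1)c1cnccn1`: > 80000 nM, a limit of the assay
Compound 2 `C/C(=N\NC(=O)c1ccc([N+](=O)[O-])cc1)c1cnccn1`: 2870 nM

For the measured compounds named here, in an ADME assay on MRC5 cells (Homo sapiens) for antiproliferative activity, read by MTT assay (on this read-out higher numbers stand for weaker inhibition and lower numbers for stronger inhibition), compound 2 gives 2870 nM, the only actual number so far. Compound 1 stands at the limit of > 80000 nM in this assay, at which 1 of the 2 values shown sits.

Compound 3 `C/C(=N\NC(=O)c1ccc(N)cc1)c1cnccn1` has amino in place of nitro on an aromatic carbon, para to a large group: amino in place of nitro on an aromatic carbon.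

Going by the values given here, one measured step bears on this change: an at least 27-fold lower number from compound 1 to compound 2 (1.44 log units; beyond the scatter), with nitro in place of hydroxy on an aromatic carbon. Compound 3 also loses the nitro, so a clear move to a higher number is expected in this assay, although that single step cannot fix its size, and amino is not hydroxy. The expected step is an 8.7-fold higher number from compound 2 to compound 3 (0.94 log units; beyond the scatter). For compound 3 the estimated value is 25000 nM, with an expected range of 7000 nM to 80000 nM.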

Compound 3, half-maximal inhibitory concentration in the MRC5 assay: > 80000 nM
Compound 3: no number, only a limit; the forecaster's own chance of this, stated with the estimate: 35%; at least 3.2-fold (0.50 log units) between middle value and limit.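

In the MRC5 assay, amino does not hold what nitro gives on this aromatic carbon, para to a large group: an at least 27-fold higher number from compound 2 to compound 3 (1.44 log units; beyond the scatter). Compound 3 sits at a limit of the assay, as compound 1 does, so the step between these two cannot be read, and of the compounds shown only compound 2 gives an actual number: the limit of > 80000 nM in the MRC5 assay, at which 2 of the 3 values shown sit. The same change also gives a more polar compound in a physicochemical assay for lipophilicity (a lower number here means a more polar compound, a higher number a more lipophilic compound), though this one pair cannot say whether that accounts for the weaker inhibition: the measured partition coefficient of compound 2, 2.1, and of compound 3, 1.3, a number 0.80 log units lower (beyond the scatter). In the physicochemical assay compound 2 gives 2.1 and compound 3 gives 1.3.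

From the compounds shown here alone, it remains open whether a nitrile or a trifluoromethyl group in the same place would also give an actual number in the MRC5 assay. The compounds shown also do not tell whether nitro would give one at another place on the ring.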